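A Halogen Swap on the Aryl Arm of a Shared Core

This account rests on a few compounds, and the source may have more. Where it says the series, first, only, none or still open, it means among the compounds named here.

Measured so far in a functional assay on HeLa cells (Homo sapiens) for antiproliferative activity, read by MTT assay; on this read-out higher numbers stand for weaker inhibition and lower numbers for stronger inhibition:
compound 1 `COc1ccc(-c2ccnc(Nc3ccc(Cl)cc3Cl)n2)cc1`: 23000 nM
compound 2 `O=[N+]([O-])c1ccc(Nc2nccc(-c3ccc(F)cc3)n2)cc1`: 3510 nM
compound 3 `COc1cccc(Nc2nccc(-c3ccc(Br)cc3)n2)c1`: 153000 nM

Among these three, compound 2 gives the lowest number in this assay, so it is the strongest inhibitor of the set. Compound 1 stands closest to it, yet its number is higher by a margin beyond the usual scatter, and compound 3 lies far further out. No two of the three differ in only one place, so none of these gaps can be tied to a single structural change.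

Compound 4 `O=[N+]([O-])c1ccc(Nc2nccc(-c3ccc(Cl)cc3Cl)n2)cc1` is the next compound to be measured. Compared with compound 2, it carries 2,4-dichlorophenyl in place of 4-fluorophenyl on an aromatic carbon. The change sits on the aromatic carbon next to the ring nitrogen and leaves the rest of the shared core untouched. Among the compounds with values here, there is no measured step of this kind to lean on; the only other compound bearing 2,4-dichlorophenyl is compound 1, and there the group occupies a different place, so its value cannot be read across directly.

For compound 4 the step of a 1.7-fold higher number from compound 2 to compound 4 (0.23 log units; within the scatter) is expected to be a modest loss or no change beyond the scatter, with a wide spread. The estimate for compound 4 is 6000 nM, within a range from 1500 nM to 25000 nM.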

Compound 4, half-maximal inhibitory concentration: 168000 nM
For compound 4 the middle estimate is 28-fold (1.45 log units) below the measured one; measured number outside the range, above it.
By their numbers in this assay, from the lowest: compound 2; then compound 1; then compounds 3 and 4 (each within the scatter of the next).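

In this assay, within the data shown here, putting 2,4-dichlorophenyl in place of 4-fluorophenyl on the aromatic carbon next to the ring nitrogen gives a 48-fold higher number from compound 2 to compound 4 (1.68 log units; beyond the scatter) and provides the first comparison in this set in which only one place differs. With the rest of the shared core unchanged, this position is clearly sensitive to the identity of its aryl group, and here the change leads to much weaker inhibition, so one halogen-bearing phenyl group cannot be assumed to stand in for another. No accompanying measurement accounts for the size of this step, so it records an outcome and does not establish a cause.

The swap also changes both the kind of halogen and the number of halogens on the ring, and this single pair cannot separate those two differences. A plain phenyl group, a phenyl group carrying a single chlorine, or a phenyl group bearing an amine or a carboxylic acid would be needed to show how far this position tolerates change and which feature of the aryl arm tracks with the loss.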